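The source may report more compounds than this note shows. Statements on the series, on what has been measured and on what is new or still open speak of the compounds shown alone.

Compound 1 `COc1ccc(-c2ccc3c(c2)C(=O)C(=O)N3Cc2ccc(Br)cc2)cc1` gives 700 nM in a functional assay on HepG2 cells (Homo sapiens) for antiproliferative activity, read by MTT assay, with a stated time of 48 h; on this read-out higher numbers stand for weaker inhibition and lower numbers for stronger inhibition.
Compound 2 `COc1ccc(CN2C(=O)C(=O)c3cc(-c4ccc(OC)cc4)ccc32)cc1` gives 50 nM in this assay.
Compound 3 `COc1ccc(-c2ccc3c(c2)C(=O)C(=O)N3Cc2ccc(C#N)cc2)cc1` gives 1000 nM in this assay.

Among these three, compound 2 stands lowest, which on this read-out means the strongest inhibition: the nearest is compound 1, separated by a 14-fold lower number from compound 1 to compound 2 (1.15 log units; beyond the scatter), and the furthest is compound 3, separated by a 20-fold higher number from compound 2 to compound 3 (1.30 log units; beyond the scatter). The third step, a 1.4-fold higher number from compound 1 to compound 3 (0.15 log units; within the scatter), is small. Each of these steps swaps one group for another on an aromatic carbon, and all three concern the same position.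

Compound 4 `COc1ccc(CN2C(=O)C(=O)c3cc(-c4ccncc4)ccc32)cc1` differs from compound 2 at a different position: pyridin-4-yl in place of 4-methoxyphenyl on an aromatic carbon. For the measured compounds named here, no measured step touches this part of the shared core, so none bears directly on the change. What the measured steps do show is that a single swap of one group on an aromatic carbon can move the read-out by a large amount in this series, or leave it within the scatter. An expectation for compound 4 therefore rests on little; a step toward weaker inhibition of moderate size is estimated, an 8.0-fold higher number from compound 2 to compound 4 (0.90 log units; beyond the scatter), with wide uncertainty in both directions. Compound 4 is expected to give 400 nM in this assay, with a range from 60 nM to 3000 nM.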

Compound 4, half-maximal inhibitory concentration: > 10000 nM
Compound 4: only a limit was reported (the forecaster's own chance of this, stated with the estimate: 5%); middle value at least 25-fold (1.39 log units) from the limit.
By their numbers in this assay, from the lowest: compound 2; then compounds 1 and 3 (each within the scatter of the next). At a limit, above all of these: compound 4.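

In this assay, for the compounds shown here, the position that no earlier step touched turns out to matter a great deal: pyridin-4-yl in place of 4-methoxyphenyl gives an at least 200-fold higher number from compound 2 to compound 4 (2.30 log units; beyond the scatter), and this step is larger than either of the large steps among compounds 1, 2 and 3, which all concern the other position. Compound 4 is held at a limit and not at a number, so this step sets only the smallest possible size of the change, and the true size remains unknown: the limit of > 10000 nM in this assay, at which 1 of the 4 values shown sits.
The swap also changes two things at once, since the group that leaves has a ring of carbon only and carries a methoxy, while the group that enters has a ring with a hetero atom and carries no methoxy.

The compounds shown therefore leave open which of these two changes accounts for the step, and a plain phenyl at this position would begin to separate them. Also open, as far as these compounds go, is how this position tolerates other groups, such as a 4-aminophenyl or a 4-carboxyphenyl, and whether pyridin-4-yl has the same effect alongside the bromo or nitrile of compounds 1 and 3.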